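The source may hold more compounds than are shown below. What is called first, only, known or untested is meant among the compounds shown, and "the series" means these compounds.

Working notes on the series, an assay on isolated protein for binding affinity to Equilibrative nucleoside transporter 1 (Homo sapiens); a higher number here means a weaker inhibitor, a lower number a stronger inhibitor. Compound 1 `CSc1ncnc2c1ncn2C1CCCCO1` gives 275000 nM. Compound 2 `Nc1nc(SCc2ccccc2Cl)c2ncn([C@@H]3O[C@H](CO)[C@@H](O)[C@H]3O)c2n1` gives 13500 nM, the lowest of the two numbers, with compound 1 a larger number beyond the scatter. Compound 3 `CSc1nc(N)nc2c1ncn2[C@@H]1O[C@H](CO)[C@@H](O)[C@H]1O` differs from compound 2 by hydrogen in place of 2-chlorophenyl on a saturated chain carbon bound to a sulfur, that is 2-chlorobenzyl to methyl. Among the measured compounds shown here, no measured pair shows this change alone; compound 1, which carries the methylsulfanyl group but lacks the amino group and the sugar, stands far higher than compound 2. For compound 3 a clear rise in the number is expected, an 11-fold higher number from compound 2 to compound 3 (1.05 log units; beyond the scatter), with an estimate of 150000 nM and a range from 30000 nM to 600000 nM.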

Compound 3, half-maximal inhibitory concentration: 204000 nM
Compound 3: middle estimate off by 1.4-fold (0.13 log units), on the low side; the range from low to high includes it.
By their numbers in this assay, from the lowest: compound 2; then compounds 3 and 1 (each within the scatter of the next).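

In this assay, among the compounds shown here, replacing (2-chlorobenzyl)sulfanyl with methylsulfanyl gives a 15-fold higher number from compound 2 to compound 3 (1.18 log units; beyond the scatter) as the first reading of this position with the amino group and the sugar unchanged. The lower number of compound 2 therefore depends strongly on the 2-chlorophenyl on a saturated chain carbon bound to a sulfur. The measurements offer no explanation for the size of this step.
From the compounds shown here alone, it remains open whether the chlorine contributes or the phenyl ring alone would suffice, as an unsubstituted benzyl would show. Going by these compounds, a longer chain, such as 2-phenylethyl, on the sulfur is equally open.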